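The source may report more compounds than this note shows. Statements on the series, on what has been measured and on what is new or still open speak of the compounds shown alone.

Of the compounds shown here, three sharing one core have been measured in an assay on isolated protein for displacement of a labelled ligand from melanin-concentrating hormone receptor 1 (Homo sapiens); a lower number here means a stronger inhibitor, a higher number a weaker inhibitor. Compound 1 `CCCc1cc(NC)c2cc(NC(=O)/C=C/c3ccc(C(F)(F)F)cc3)ccc2n1` gives 1.5 nM. Compound 2 `CCCc1cc(N2CCCCC2)c2cc(NC(=O)/C=C/c3ccc(C(F)(F)F)cc3)ccc2n1` returns only the assay limit of > 4000 nM, a limit rather than a number. Compound 3 `CCCc1cc(N(C)C)c2cc(NC(=O)/C=C/c3ccc(C(F)(F)F)cc3)ccc2n1` gives 43 nM, which is the higher of the two numbers shown; its nearest neighbour is compound 1, and the step of a 29-fold higher number from compound 1 to compound 3 (1.46 log units; beyond the scatter) sets compound 3 clearly apart. The other step into compound 3, an at least 93-fold lower number from compound 2 to compound 3 (1.96 log units; beyond the scatter), runs the opposite way.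

Compound 4 `CCCc1cc(NC2CCC2)c2cc(NC(=O)/C=C/c3ccc(C(F)(F)F)cc3)ccc2n1` is not yet measured. It differs from compound 3 in one place: cyclobutylamino in place of dimethylamino on an aromatic carbon. This change brings back the hydrogen-bond donor that compound 1 carries and compound 3 lacks, so the step of a 29-fold higher number from compound 1 to compound 3 (1.46 log units; beyond the scatter) bears on it most directly, while the step of an at least 93-fold lower number from compound 2 to compound 3 (1.96 log units; beyond the scatter) bears on the size of the group carried on that nitrogen. Compound 4 is therefore expected to show a lower number than compound 3, an estimated step of an 8.6-fold lower number from compound 3 to compound 4 (0.93 log units; beyond the scatter), with compound 1 as the closer reference. For compound 4 the expected value is 5 nM, within a range from 1 nM to 30 nM.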

Compound 4, half-maximal inhibitory concentration: 18 nM
Beside the measured number, compound 4's estimate is 3.6-fold (0.56 log units) below it; the measured number falls inside the stated range.
By their numbers in this assay, from the lowest: compound 1; then compound 4; then compound 3. At a limit, above all of these: compound 2.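

In this assay, the hydrogen-bond donor on this nitrogen does not by itself recover the number of compound 1: with cyclobutylamino in place of dimethylamino the gain is only modest, a 2.4-fold lower number from compound 3 to compound 4 (0.38 log units; beyond the scatter), while cyclobutyl in place of methyl on the same nitrogen costs far more, a 12-fold higher number from compound 1 to compound 4 (1.08 log units; beyond the scatter). A carbon ring at this position is nevertheless compatible with binding when it hangs from the nitrogen as cyclobutylamino, as against the piperidin-1-yl of compound 2, an at least 220-fold lower number from compound 2 to compound 4 (2.34 log units; beyond the scatter). That last step starts from a limit, not a number: the limit of > 4000 nM in this assay, at which 1 of the 4 values shown sits.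

The compounds shown leave open how the number moves from methylamino to cyclobutylamino, which an ethyl or cyclopropyl group on that nitrogen would show. They also leave open whether an open chain such as butyl there matches the cyclobutyl ring, and how the unsubstituted amine behaves.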